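Series notes: 2-hydroxypyridin-4-yl in place of 3,5-difluorophenyl

This account rests on a few compounds, and the source may have more. Where it says the series, first, only, none or still open, it means among the compounds named here.

Compound 1 `O=C(O)Cc1sc(C(c2ccc(F)cc2)c2ccc(F)cc2)nc1-c1cc(F)cc(F)c1` and compound 2 `O=C(O)Cc1sc(C(c2ccccc2)c2ccccc2)nc1-c1ccc(F)cc1` share the same core and the same carboxymethyl group and differ in their aromatic substituents. In an in vitro functional assay on HEK285-7 cells for antagonist activity at prostaglandin D2 receptor 2 (Homo sapiens), read by BRET and beta-arrestin recruitment (a higher number here means a larger maximal response, a lower number a smaller maximal response), compound 1 gives 80%. Compound 2 gives 80% in this assay. Compound 1 therefore stands level with compound 2 at the digits shown; the gap lies within the scatter, so no order between the two can be read, and no step between measured compounds is available for this series.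

Compound 3 `O=C(O)Cc1sc(C(c2ccc(F)cc2)c2ccc(F)cc2)nc1-c1ccnc(O)c1` has not yet been measured. It differs from compound 1 by 2-hydroxypyridin-4-yl in place of 3,5-difluorophenyl on an aromatic carbon. Since both compound 1 and compound 2 reach the same maximal response, the step is expected to stay within the scatter, with no direction beyond it, as a number 5 percentage points lower from compound 1 to compound 3 (within the scatter). Compound 3 is expected to give 75% in this assay, with a range from 55% to 95%.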

Compound 3, largest response reached (reported as efficacy), in percent of the reference or control that the assay uses: 60%
The estimate for compound 3 lay 15 percentage points above the measured number; low and high end bracket the measured number.
By their numbers in this assay, from the lowest: compound 3; then compounds 1 and 2 (each within the scatter of the next).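

In this assay, for the compounds shown here, 2-hydroxypyridin-4-yl in place of 3,5-difluorophenyl gives a number 20 percentage points lower from compound 1 to compound 3 (beyond the scatter), the first step that lies beyond the scatter. The aromatic carbon next to the ring nitrogen and next to the ring atom that bears a carboxymethyl group is therefore not indifferent to the group it carries, at least for this exchange of a carbon-only ring for one with 1 hetero atom. Nothing available bears on why the maximal response falls.

This single exchange alters the ring atoms, the hydroxyl group and the fluorines together, and the compounds shown do not separate these changes. Also open, from the compounds shown here alone, is where a plain pyridin-4-yl, or a pyridine ring carrying an amine instead of the hydroxyl group, would stand at this position.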